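This account rests on a few compounds, and the source may have more. Where it says the series, first, only, none or still open, it means among the compounds named here.

Compound 1, `COc1ccc(-c2cn(C/C=C3\OC(=O)C(OCc4ccccc4)=C3OCc3ccccc3)nn2)cc1`, in an ADME assay on HFF cells (Homo sapiens) for cytotoxicity, read by MTT assay, with a stated time of 72 h (on this read-out higher numbers stand for weaker inhibition and lower numbers for stronger inhibition), gives > 100000 nM, which is a limit of the assay and not a number.
Compound 2, `Cc1ccc(-c2cn(C/C=C3\OC(=O)C(OCc4ccccc4)=C3OCc3ccccc3)nn2)cc1`, gives > 100000 nM, likewise a limit.
Compound 3, `O=C1O[C@H]([C@@H](O)Cn2cc(CNS(=O)(=O)c3ccc(Cl)cc3F)nn2)C(OCc2ccccc2)=C1OCc1ccccc1`, gives 20 nM.

Within the data shown here, compound 3 therefore stands alone in this assay: it is the only measured number, while compounds 1 and 2 sit at the limit of > 100000 nM in this assay, at which 2 of the 3 values shown sit. Among the measured compounds shown here, the only step between measured compounds, a step that the two limits leave unreadable from compound 1 to compound 2, runs from one limit to another and so says nothing about size or direction.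

Compound 4, `O=C1O[C@H]([C@@H](O)Cn2cc(CCCCl)nn2)C(OCc2ccccc2)=C1OCc1ccccc1`, differs from compound 3 in a single place: 2-chloroethyl in place of ((4-chloro-2-fluorophenyl)sulfonyl)amino on a saturated chain carbon bound to an aromatic carbon. For the measured compounds named here, no measured step touches this change. Compounds 1 and 2 carry a different core from compound 3 and do not share the group that leaves, so their limits give no guide, and the expectation rests on the structural change alone.

Compound 3 gives 20 nM with the group that leaves in place. With 2-chloroethyl in its place, a loss of cytotoxic strength is expected for compound 4, a step of a 150-fold higher number from compound 3 to compound 4 (2.18 log units; beyond the scatter). Compound 4 is accordingly estimated at 3000 nM, with a likely range from 200 nM to 60000 nM.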

Compound 4, half-maximal inhibitory concentration: 27100 nM
For compound 4 the middle estimate is 9.0-fold (0.96 log units) below the measured one; the measured number falls inside the stated range.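

Among these compounds, until now the only step in this assay ran between two limits and could not be read, whereas replacing ((4-chloro-2-fluorophenyl)sulfonyl)amino with 2-chloroethyl gives a 1400-fold higher number from compound 3 to compound 4 (3.13 log units; beyond the scatter) and so puts a size on a change for the first time. It shows that, with the core of compound 3 held fixed, the group on this saturated chain carbon bound to an aromatic carbon has a large bearing on the read-out, so the core alone does not set the value of compound 3. Nothing given here accounts for the size of this step.

As far as these compounds go, the aromatic ring and the sulfonyl amino link leave together, so it stays open whether either of them alone would carry the step or whether both are needed. Also open, from the compounds shown here alone, is how a simple amine, a carboxylic acid or a longer chain ending in chlorine would read at this place in this assay, and with it whether the 2-chloroethyl group sits near the weak end of what this position allows.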